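Ester branching in a furyl dihydropyrimidinone series

A few compounds are considered here, and "the series" means these few. Any claim that something is new, unique, unknown or untested is made for them only; others in the source may bear on it.

Measured so far:
compound 1 `COC(=O)C1=C(C)N(C)C(=O)NC1c1ccco1` — 9%
compound 2 `CC1=C(C(=O)OCC(C)C)C(c2ccco2)NC(=O)N1C` — 23%

Among the measured compounds shown here, in an assay on membranes from HeLa cells for displacement of a labelled ligand from adenosine receptor A3 (Homo sapiens), read by scintillation counting, with a stated time of 180 min, tested at 1 uM (a higher number here means more inhibition at the concentration tested (going by the name of the read-out), a lower number less inhibition), compound 2 gives the higher of the two numbers; the only step in hand, a number 14 percentage points higher from compound 1 to compound 2 (beyond the scatter), is modest. Compound 3 `CC1=C(C(=O)OC(C)(C)C)C(c2ccco2)NC(=O)N1C` differs from compound 2 by tert-butyl in place of isobutyl on an oxygen next to a carbonyl group. For the measured compounds named here, no measured step swaps one four-carbon chain for another, so that step gives only a loose guide; the change is expected to be within the scatter, a number 2 percentage points higher from compound 2 to compound 3 (within the scatter). Compound 3 is therefore estimated at 25%, between 10% and 40%.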

Compound 3, a percentage reported as inhibition, at one concentration (the size of the read-out at that concentration, not a potency): 54%
Compound 3: middle estimate off by 29 percentage points, on the low side; measured number above the stated range.
By their numbers in this assay, from the lowest: compound 1; then compound 2; then compound 3.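

In this assay, the same atoms joined differently at this oxygen next to a carbonyl group separate two esters: tert-butyl in place of isobutyl gives a number 31 percentage points higher from compound 2 to compound 3 (beyond the scatter). Set against the methyl ester, tert-butyl gives a number 45 percentage points higher from compound 1 to compound 3 (beyond the scatter), so the shape of the chain on this oxygen counts for more here than the step to isobutyl alone suggested. Nothing at hand accounts for the gain.

Open, from the compounds shown here alone, is whether isopropyl or cyclohexyl esters follow tert-butyl, and whether a carboxylic acid or an amide at this place keeps the number. These single-concentration percentages also leave the potency of compound 3 open.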